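A few compounds are considered here, and "the series" means these few. Any claim that something is new, unique, unknown or untested is made for them only; others in the source may bear on it.

Compound 1 `COc1ccc(CN(C(=O)CSc2nc3ccccc3s2)c2cc(OC)c(OC)c(OC)c2)cc1O` gives 2110 nM in a functional assay on PC-3 cells (Homo sapiens) for antiproliferative activity, read by MTT assay, with a stated time of 48 h (a higher number here means a weaker inhibitor, a lower number a stronger inhibitor), the lowest of the three numbers at hand. Compound 2 `COc1ccc(CN(C(=O)CSc2nc3cc(Br)ccc3s2)c2cc(OC)c(OC)c(OC)c2)cc1O` gives 8210 nM and compound 3 `COc1ccc(CN(C(=O)CSc2nc3c(C)cccc3s2)c2cc(OC)c(OC)c(OC)c2)cc1O` gives 12300 nM; each of them adds a group on an aromatic carbon of the shared core, and each weakens the compound: a 3.9-fold higher number from compound 1 to compound 2 (0.59 log units; beyond the scatter) and a 5.8-fold higher number from compound 1 to compound 3 (0.77 log units; beyond the scatter). Compound 4 `COc1ccc(CN(C(=O)CSc2nc3ccccc3s2)c2cc(OC)c(OC)c(OC)c2)cc1OC` differs from compound 1 in another place: methyl in place of hydrogen on an oxygen on an aromatic ring. Within the data shown here, no measured step touches this hydroxy, so the two measured steps give no direct guide; they show only that small changes to compound 1 have so far raised the number. A modest rise is therefore expected, a 2.1-fold higher number from compound 1 to compound 4 (0.33 log units; beyond the scatter), though a change within the scatter cannot be ruled out. Compound 4 is estimated at 4500 nM, with a range from 1500 nM to 14000 nM.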

Compound 4, half-maximal inhibitory concentration: > 80000 nM
Compound 4 gave a limit, no number; the forecaster's own chance of this, stated with the estimate: 10%; middle value at least 17-fold (1.24 log units) away from the limit.
By their numbers in this assay, from the lowest: compound 1; then compounds 2 and 3 (each within the scatter of the next). At a limit, above all of these: compound 4.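

Turning the hydroxy into a methoxy, 3-hydroxy-4-methoxyphenyl to 3,4-dimethoxyphenyl, gives an at least 37-fold higher number from compound 1 to compound 4 (1.57 log units; beyond the scatter) as the largest step seen so far. Compound 4 gives a limit of the assay and not a number: the limit of > 80000 nM in this assay, at which 1 of the 4 values shown sits. A single added methyl on this oxygen therefore costs far more than the aromatic-carbon changes, which gave a 3.9-fold higher number from compound 1 to compound 2 (0.59 log units; beyond the scatter) and a 5.8-fold higher number from compound 1 to compound 3 (0.77 log units; beyond the scatter) as their steps.

Still open, as far as these compounds go, is whether the free hydroxy itself is required, or whether an amine in its place would keep the number near that of compound 1. A longer chain on the oxygen, such as ethoxy, is equally untested by the compounds shown, and they give no reason for the loss.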